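The source may hold more compounds than are shown below. What is called first, only, known or untested is meant among the compounds shown, and "the series" means these compounds.

Working notes on the series.

Compound 1 `COC1Cc2sccc2C2(CCNCC2)O1` is the parent here. Among the measured compounds shown here, in an assay on membranes from brain for displacement of a labelled ligand from Sigma non-opioid intracellular receptor 1 (Cavia porcellus) (a lower number here means a stronger inhibitor, a higher number a weaker inhibitor), compound 1 gives 602 nM, the highest of the two numbers so far; the only other measured member, compound 2 `COc1ccc(CN2CCC3(CC2)OC(OC)Cc2sccc23)cc1`, gives 2.2 nM in this assay, a far lower number than compound 1, and the gap between the two lies well beyond the scatter.

The next compound, compound 3 `CCCCCCCCN1CCC2(CC1)OC(OC)Cc1sccc12`, keeps the core of compound 1 and changes it in one place: octyl in place of hydrogen on an amine nitrogen in a ring. For the measured compounds named here, no measured pair shows this exact change, so the size of the step has to be estimated. Compound 2 shows that a substituent on that same nitrogen goes with a much lower number than compound 1, and a step in the same direction, large and beyond the scatter, is expected for compound 3 in this assay. The estimated step is a 120-fold lower number from compound 1 to compound 3 (2.08 log units; beyond the scatter). Compound 3 is therefore expected to give about 5 nM in this assay, with a likely range from 1 nM to 25 nM.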

Compound 3, inhibition constant: 5.1 nM
Compound 3: the middle estimate sits 1.0-fold (0.01 log units) below what was measured; the measured number falls inside the stated range.
By their numbers in this assay, from the lowest: compound 2; then compound 3; then compound 1.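

Compound 3 shows that this amine nitrogen in a ring does not need an aromatic group for a low number: octyl, with no ring and no hydrogen-bond acceptors, gives a 120-fold lower number from compound 1 to compound 3 (2.07 log units; beyond the scatter) in this assay. Heptyl in place of 4-methoxyphenyl on the saturated chain carbon bound to that nitrogen still costs something, with a 2.3-fold higher number from compound 2 to compound 3 (0.37 log units; beyond the scatter), a modest step that remains beyond the scatter and is small beside the step gained by substituting the nitrogen at all. No measurement here bears on why either substituent goes with a lower number.

Octyl is the only plain chain among the compounds shown, so how the number in this assay moves with chain length remains open, for instance with a butyl chain or a dodecyl chain. Also open, on these data alone, is whether a benzyl group without the methoxy would sit nearer compound 2 or compound 3.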